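Working notes: from compound 3 to compound 4

The source may report more compounds than this note shows. Statements on the series, on what has been measured and on what is new or still open speak of the compounds shown alone.

Measured in a functional assay on MCF7 cells (Homo sapiens) for inhibition, read by sulforhodamine B assay, with a stated time of 48 h, tested at 50 uM; a higher number here means more inhibition of growth at the concentration tested, a lower number less inhibition of growth:
Compound 1 `COc1ccc([C@@H]2C/C(=N/OCc3cn(-c4ccc(Cl)cc4C)nn3)c3cc(CC=C(C)C)c(OC)cc3O2)cc1`: 37%
Compound 2 `COc1ccc([C@@H]2C/C(=N/OCc3cn(-c4ccc(C(N)=O)cc4)nn3)c3cc(CC=C(C)C)c(OC)cc3O2)cc1`: 100%
Compound 3 `C#CCO/N=C1/C[C@@H](c2ccc(OC)cc2)Oc2cc(OC)c(CC=C(C)C)cc21`: 61%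

Compound 3 stands second of the three, beyond the scatter above compound 1 and beyond the scatter below compound 2.

Compound 4 `COc1ccc([C@@H]2C/C(=N/OCc3cn(-c4cccnc4Cl)nn3)c3cc(CC=C(C)C)c(OC)cc3O2)cc1` differs from compound 3 in one place, with 1-(2-chloropyridin-3-yl)-1H-1,2,3-triazol-4-yl in place of ethynyl on a saturated chain carbon bound to an oxygen on an unsaturated carbon.

Among the compounds with values here, no measured step makes this exact change. The nearest evidence is the large step of a number 63 percentage points higher from compound 1 to compound 2 (beyond the scatter), with 4-carbamoylphenyl in place of 4-chloro-2-methylphenyl on an aromatic nitrogen. The aryl group on that nitrogen can therefore move the number widely, and compound 4 carries neither group. Its chlorine-bearing ring has a closer counterpart in compound 1 at 37% than in compound 2 at 100%, so the middle is set slightly on the lower side.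

The estimated step is a number 9 percentage points lower from compound 3 to compound 4 (within the scatter), so no change beyond the scatter is expected in this assay, although the uncertainty is wide. For compound 4 the estimate is 52%, with an expected range of 28% to 88%.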

Compound 4, percent growth inhibition at one concentration: 35%
Compound 4: the middle estimate sits 17 percentage points above what was measured, within the range that was stated.
By their numbers in this assay, from the lowest: compounds 4 and 1 (each within the scatter of the next); then compound 3; then compound 2.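

In this assay the change to 1-(2-chloropyridin-3-yl)-1H-1,2,3-triazol-4-yl on a saturated chain carbon bound to an oxygen on an unsaturated carbon gives a number 26 percentage points lower from compound 3 to compound 4 (beyond the scatter) and so shows that this larger group can lower the number relative to ethynyl. On the aromatic nitrogen, 2-chloropyridin-3-yl in place of 4-carbamoylphenyl gives a number 65 percentage points lower from compound 2 to compound 4 (beyond the scatter) while in place of 4-chloro-2-methylphenyl it gives a number 2 percentage points lower from compound 1 to compound 4 (within the scatter) and leaves those two aryl groups not told apart. Among these three aryl groups, only 4-carbamoylphenyl stands apart.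

Open, on these data alone, is whether that result depends on the carbamoyl group itself, which a phenyl ring carrying a carboxylic acid or an amine in its place would test. Nothing shown bears on why these aryl groups differ.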